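The source may report more compounds than this note shows. Statements on the series, on what has been measured and on what is new or still open speak of the compounds shown alone.

Of the compounds shown here, three sharing one core have been measured in a functional assay on RT-112 cells (Homo sapiens) for antiproliferative activity, read by MTT assay, with a stated time of 72 h; a higher number here means a weaker inhibitor of growth, a lower number a stronger inhibitor of growth. Compound 1 (`COc1cc(Nc2ncnc3c(NC(=O)Nc4cc(Cl)cc(Cl)c4)cccc23)cc(OC)c1`) gives 30.2 nM, compound 2 (`COc1cc(Nc2ncnc3c(NC(=O)Nc4cc(Cl)c(Cl)cc4Cl)cccc23)cc(OC)c1`) gives 4890 nM, and compound 3 (`COc1cc(Nc2ncnc3c(NC(=O)Nc4ccc(C(F)(F)F)cc4Cl)cccc23)cc(OC)c1`) gives 1080 nM, the middle of the three numbers. Compound 4 (`COc1cc(Nc2ncnc3c(NC(=O)Nc4cccc(C(F)(F)F)c4F)cccc23)cc(OC)c1`) has not yet been measured. It carries 2-fluoro-3-(trifluoromethyl)phenyl in place of 2-chloro-4-(trifluoromethyl)phenyl on an amide-type nitrogen.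

All three measured steps change the group at this same place, and all lie beyond the scatter. The step of a 160-fold higher number from compound 1 to compound 2 (2.21 log units; beyond the scatter) and the step of a 36-fold higher number from compound 1 to compound 3 (1.55 log units; beyond the scatter) were large, while the step of a 4.5-fold lower number from compound 2 to compound 3 (0.66 log units; beyond the scatter) was modest. Going by the values given here, none of the measured compounds carries the entering group, so the size of the coming step is uncertain. A modest move to a lower number is expected, an expectation that rests on the room shown by a 36-fold higher number from compound 1 to compound 3 (1.55 log units; beyond the scatter). The expected step is a 2.7-fold lower number from compound 3 to compound 4 (0.43 log units; beyond the scatter). For compound 4 the estimated value is 400 nM, with an expected range of 80 nM to 2000 nM.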

Compound 4, concentration for 50% growth inhibition: 471 nM
The estimate for compound 4 lay 1.2-fold (0.07 log units) below the measured number, and the stated range covers the measured number.
By their numbers in this assay, from the lowest: compound 1; then compound 4; then compound 3; then compound 2.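

Moving from 2-chloro-4-(trifluoromethyl)phenyl to 2-fluoro-3-(trifluoromethyl)phenyl keeps the heavy-atom count and the carbon-only aromatic ring, yet it still shifts the number (a 2.3-fold lower number from compound 3 to compound 4 (0.36 log units; beyond the scatter)), so this position distinguishes between groups of the same size by that count. The new group also improves clearly on 2,4,5-trichlorophenyl (a 10-fold lower number from compound 2 to compound 4 (1.02 log units; beyond the scatter)), but it does not match 3,5-dichlorophenyl (a 16-fold higher number from compound 1 to compound 4 (1.19 log units; beyond the scatter)), which leaves compound 1 with the lowest number of the four. No evidence is available on why these groups differ. Compound 4 exchanges chlorine for fluorine and relocates the trifluoromethyl group in a single step, so the share of each change remains unresolved. Going by these compounds, it also remains open whether 3,5-bis(trifluoromethyl)phenyl or 3,5-dimethoxyphenyl on this nitrogen would come close to the number of compound 1.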